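A few compounds are considered here, and "the series" means these few. Any claim that something is new, unique, unknown or untested is made for them only; others in the source may bear on it.

Within the data shown here, compound 1 `NC(=O)[C@@H]1CCN1Cc1ccc(OCc2cccc(F)c2)cc1Cl` gives 2130 nM in an assay on Sf9 cells for inhibition of Amine oxidase [flavin-containing] A (Homo sapiens), with stated times of 15 min and 60 min (on this read-out lower numbers stand for stronger inhibition and higher numbers for weaker inhibition), the lowest of the three numbers measured so far. Compound 3 `C#CCN(Cc1ccc(OCc2cccc(F)c2)cc1F)[C@@H](C)C(N)=O` comes nearest to it with 8710 nM, and compound 2 `C[C@H](NCc1ccc(OCc2cccc(F)c2)cc1Cl)C(N)=O` lies furthest with 12000 nM. Among the measured compounds shown here, the only step between two compounds that differ in a single place, a 5.6-fold higher number from compound 1 to compound 2 (0.75 log units; beyond the scatter), concerns a different part of the molecule. Compound 4 `NC(=O)[C@@H]1CCN1Cc1ccc(OCc2cccc(F)c2)cc1F` is still to be measured in this assay; it differs from compound 1 by fluoro in place of chloro on an aromatic carbon. For the measured compounds named here, no measured step tests this exchange on its own: compound 3 carries the fluoro but also another change, so its value cannot be read as the effect of the halogen alone. A modest step, direction uncertain, is therefore expected, a 1.5-fold higher number from compound 1 to compound 4 (0.18 log units; within the scatter). Compound 4 is estimated at 3200 nM, within 1200 nM to 8500 nM.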

Compound 4, half-maximal inhibitory concentration: 18600 nM
For compound 4 the middle estimate is 5.8-fold (0.76 log units) below the measured one; measured number above the stated range.
By their numbers in this assay, from the lowest: compound 1; then compounds 3, 2 and 4 (each within the scatter of the next, the first and the last beyond it).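

In this assay, among these compounds, the halogen at this position is not interchangeable: fluoro in place of chloro, ortho to the (2-carbamoylazetidin-1-yl)methyl group, gives an 8.7-fold higher number from compound 1 to compound 4 (0.94 log units; beyond the scatter), although only one heavy atom changes. Among the compounds shown here, this is the first reading of the halogen exchange on its own, and chloro gives the lower number in this pair. Nothing measured here explains the difference.

As far as these compounds go, whether bromo or a methyl group at this position would give a lower number than chloro remains open. So does whether the same exchange has a similar effect with the (1-carbamoylethyl)amino group of compound 2.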